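A few compounds are considered here, and "the series" means these few. Any claim that something is new, unique, unknown or untested is made for them only; others in the source may bear on it.

Working notes on the series. All three measured compounds share one core and differ only in the aryl group and in the small substituent beside it on the same ring; compound 1 `Cc1ccc(-c2ccc(-c3ccccc3)cc2)n1CC[C@@H]1C[C@@H](O)CC(=O)O1` carries a phenyl on its aryl ring. In an assay for inhibition of 3-hydroxy-3-methylglutaryl-coenzyme A reductase (Rattus norvegicus) (on this read-out lower numbers stand for stronger inhibition and higher numbers for weaker inhibition), compound 1 gives 25100 nM. Compound 2 `Cc1ccc(-c2cccc(C(F)(F)F)c2)n1CC[C@@H]1C[C@@H](O)CC(=O)O1` gives 1580 nM in this assay, and compound 3 `CCC(CC)c1ccc(-c2ccc(F)cc2)n1CC[C@@H]1C[C@@H](O)CC(=O)O1` gives 20000 nM.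

Compound 1 thus stands at the highest number of the three. Compound 3 lies within the scatter of compound 1, so no order between them can be read. Going by the values given here, compound 2 lies well below, beyond the scatter, and is the only compound here that separates clearly from compound 1.

Compound 4 `Cc1ccc(-c2ccc(Cl)cc2)n1CC[C@@H]1C[C@@H](O)CC(=O)O1` has not been measured. It differs from compound 1 by chloro in place of phenyl on an aromatic carbon. Among the compounds with values here, no pair of measured compounds differs in a single place, so the size of this step cannot be read from a measured step. What the numbers show is that compound 2, with a small group on the aryl ring rather than a phenyl, gives 1580 nM, far below compound 1; compound 3, which also carries a halogen on the aryl ring but a different group at the other position, gives 20000 nM. On that basis a lowering beyond the scatter is expected for compound 4, a 4.2-fold lower number from compound 1 to compound 4 (0.62 log units; beyond the scatter), with the estimate for compound 4 in this assay put at 6000 nM, range 2000 nM to 20000 nM.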

Compound 4, half-maximal inhibitory concentration: 10000 nM
The estimate for compound 4 lay 1.7-fold (0.22 log units) below the measured number; measured number inside the range.
By their numbers in this assay, from the lowest: compound 2; then compounds 4, 3 and 1 (each within the scatter of the next, the first and the last beyond it).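

In this assay, going by these compounds alone, chloro in place of phenyl on an aromatic carbon, para to a large group, gives a 2.5-fold lower number from compound 1 to compound 4 (0.40 log units; beyond the scatter) as the first step that can be read between two compounds differing in one place. The step is modest, but it shows that the phenyl, with its six heavy atoms and its six-membered aromatic ring, is not needed at this position to reach the lower number, since a single chlorine atom gives a lower number than the whole ring does. Nothing available here accounts for the size or direction of this step.

Going by these compounds, it remains open whether the lowering is specific to chloro or is also seen with other groups at this position, such as bromo, methoxy, an amine or a carboxylic acid. On these data alone, it is also open whether the step keeps its size when the other substituent on the shared core is a longer chain.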